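A few compounds are considered here, and "the series" means these few. Any claim that something is new, unique, unknown or untested is made for them only; others in the source may bear on it.

Going by the values given here, compound 2 `CCCCCCCCc1cn(C(c2ccccc2)c2cc3cc(Br)ccc3nc2OC)nn1` sits at the lower of the two numbers so far recorded in an ADME assay on PC-3 cells (Homo sapiens) for cytotoxicity, read by sulforhodamine B assay, with a stated time of 48 h, tested at 10 uM (on this read-out higher numbers stand for more inhibition at the one concentration tested (going by the name of the read-out) and lower numbers for less inhibition), with compound 2 giving 2.27%. Among the compounds with values here, its only neighbour, compound 1 `CCCCCCc1cn(C(c2ccccc2)c2cc3cc(Br)ccc3nc2OC)nn1`, gives 2.32% in this assay, and the single measured step of a number 0.1 percentage points lower from compound 1 to compound 2 (within the scatter) lies within the scatter, so the two compounds are indistinguishable on this read-out.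

Compound 3 `COc1nc2ccc(Br)cc2cc1C(c1ccccc1)n1cc(C2CC2)nn1` is the next compound to be measured. It differs from compound 2 by cyclopropyl in place of octyl on an aromatic carbon. Within the data shown here, no measured step swaps a chain for a ring at this position; the only step on record, a lengthening of the chain, moved the number by nothing that counts. On that basis compound 3 is expected to stay near the floor of this assay, with an expected step of a number 0.7 percentage points higher from compound 2 to compound 3 (within the scatter). Compound 3 is therefore estimated at 3%, with a range from -6% to 13%.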

Compound 3, a percentage reported as inhibition, at one concentration (the size of the read-out at that concentration, not a potency): 22.6%
For compound 3 the middle estimate is 19.6 percentage points below the measured one; measured number above the stated range.
By their numbers in this assay, from the lowest: compounds 2 and 1 (each within the scatter of the next); then compound 3.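

Replacing either chain with cyclopropyl on this aromatic carbon of the five-membered ring gives a number 20.3 percentage points higher from compound 2 to compound 3 (beyond the scatter) and a number 20.3 percentage points higher from compound 1 to compound 3 (beyond the scatter) in this assay where the earlier hexyl and octyl pair showed nothing beyond the scatter. This position therefore does respond to the group it carries, though the two chains alone gave no sign of it. Nothing measured on these compounds accounts for the step.

With only these three compounds, the presence of a ring and the smaller count of carbons change together, so the two cannot be told apart as the source of the step. An open-chain group as short as ethyl or isopropyl, set against a larger ring such as cyclohexyl, would be needed to separate them.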